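The source may hold more compounds than are shown below. What is called first, only, known or untested is meant among the compounds shown, and "the series" means these compounds.

Compound 2 `c1ccc(C(CCc2nnn[nH]2)Cc2cccc(OCc3ccc4ccccc4n3)c2)cc1` gives the lowest of the two numbers recorded in an assay on membranes from lung (Cavia porcellus) for binding affinity to cysteinyl leukotriene receptor (Homo sapiens) (on this read-out higher numbers stand for weaker inhibition and lower numbers for stronger inhibition), namely 14 nM. Compound 1 `CC(CCCc1cccc(OCc2ccc3ccccc3n2)c1)C(=O)O` gives 85 nM in this assay, a gap beyond the usual scatter. Compound 3 `CC(CCc1nnn[nH]1)Cc1cccc(OCc2ccc3ccccc3n2)c1` has not yet been measured; it differs from compound 2 by methyl in place of phenyl on a saturated chain carbon bound to two saturated chain carbons. For the measured compounds named here, no measured pair shows this exchange, so its size cannot be read from the data; the expectation is a moderate step toward weaker inhibition, a 3.6-fold higher number from compound 2 to compound 3 (0.55 log units; beyond the scatter), for compound 3. Compound 3 is therefore estimated at 50 nM, within a range from 15 nM to 200 nM.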

Compound 3, inhibition constant: 34 nM
The estimate for compound 3 lay 1.5-fold (0.17 log units) above the measured number; measured number inside the range.
By their numbers in this assay, from the lowest: compound 2; then compound 3; then compound 1.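

In this assay, phenyl on a saturated chain carbon bound to two saturated chain carbons gives way to methyl at a modest cost, with a 2.4-fold higher number from compound 2 to compound 3 (0.39 log units; beyond the scatter) for this exchange. Placing 3-(1H-tetrazol-5-yl)-1-methylpropyl instead of 3-carboxybutyl on a saturated chain carbon bound to an aromatic carbon brings a 2.5-fold lower number from compound 1 to compound 3 (0.40 log units; beyond the scatter) as a modest gain. Nothing at hand explains either step. Still open, from the compounds shown here alone, is how hydrogen, ethyl or cyclohexyl would compare with phenyl and methyl at this place, and how a carboxylic acid would fare on the chain carrying phenyl.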